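This account rests on a few compounds, and the source may have more. Where it says the series, first, only, none or still open, it means among the compounds named here.

Compound 1 `N#CC1=C(N)Oc2c(c3nc4ccccc4nc3c3ccccc23)C12C(=O)N(Cc1cnnn1-c1ccccc1Cl)c1ccccc12` carries a 1-(2-chlorophenyl)-1H-1,2,3-triazol-5-yl group. In a functional assay on HCT-116 cells (Homo sapiens) for antiproliferative activity, read by MTT assay, with a stated time of 48 h (a higher number here means a weaker inhibitor, a lower number a stronger inhibitor), compound 1 gives only the limit of the assay, > 50000 nM. Compound 2 `N#CC1=C(N)Oc2c(c3nc4ccccc4nc3c3ccccc23)C12C(=O)N(Cc1cnnn1-c1cccc(Br)c1)c1ccccc12` differs from it by 3-bromophenyl in place of 2-chlorophenyl on an aromatic nitrogen. In this assay compound 2 likewise gives only a limit, > 50000 nM. The step that the two limits leave unreadable from compound 1 to compound 2 cannot be read, because both values sit at the limit of > 50000 nM in this assay, at which 3 of the 3 values shown sit. Compound 3 `N#CC1=C(N)Oc2c(N)cc3nc4ccccc4nc3c2C12C(=O)N(Cc1cnnn1-c1ccccc1Cl)c1ccccc12` has another core; how its core differs from that of compound 1 is not broken down here. In this assay compound 3 again gives only a limit, > 50000 nM. Compound 4 `N#CC1=C(N)Oc2c(N)cc3nc4ccccc4nc3c2C12C(=O)N(Cc1cnnn1-c1cccc(Br)c1)c1ccccc12`, for which no value is available, differs from compound 3 by 3-bromophenyl in place of 2-chlorophenyl on an aromatic nitrogen, the same kind of change as that from compound 1 to compound 2, at a place described in the same words. The measured step of that change is unreadable, and the expectation for compound 4 rests on compound 3 alone. Because compound 3 gives only the limit > 50000 nM, compound 4 is expected to stay at that level, with an expected step of a number no higher from compound 3 to compound 4 (the limit leaves the size open). Compound 4 is estimated at 50000 nM in this assay, between 20000 nM and 200000 nM, most probably reported again only as a limit.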

Compound 4, half-maximal inhibitory concentration: 26100 nM
Beside the measured number, compound 4's estimate is 1.9-fold (0.28 log units) above it; low and high end bracket the measured number.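

On the core of compound 3, putting 3-bromophenyl in place of 2-chlorophenyl gives an at least 1.9-fold lower number from compound 3 to compound 4 (0.28 log units; that floor lies within the scatter) in this assay. Going by these compounds, this floor alone does not establish a real difference, and the true size stays open, as compound 3 stands only at a limit. Compound 4 gives a number, 26100 nM. The same change on the core of compound 1 cannot be read, so the compounds do not show whether it carries from one core to the other, because both ends of that step are limits: the limit of > 50000 nM in this assay, at which 3 of the 4 values shown sit.

The compounds shown leave open whether the halogen or its place on the phenyl ring matters, since the two change together and neither 2-bromophenyl nor 3-chlorophenyl stands among them. Also open, on these data alone, is how an amine or a carboxylic acid on that phenyl ring would read in this assay on either core.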